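The compounds below may be only part of what the source reports. "The series", "measured", "known", "first", "only" and "open" are said of these compounds alone.

Two compounds of this series have numbers. In a functional assay on Sf9 cells for antagonist activity at histamine H2 receptor (Homo sapiens), with stated times of 2 min and 20 min (on this read-out higher numbers stand for higher potency (the scale is a negative logarithm) and lower numbers for lower potency), compound 1 `N/C(=N\C(=O)CC(c1ccccc1)c1ccccc1)NCCCc1ccccc1` gives 5.89, and compound 2 `CC(CC(=O)/N=C(\N)NCCCc1cccnc1)c1ccccc1` gives 5.27, the lower of the two, with the gap to compound 1 beyond the scatter. Compound 3 `N/C(=N\C(=O)CC(c1ccccc1)c1ccccc1)NCCCc1cccnc1` is not yet measured; it differs from compound 2 by phenyl in place of methyl on a saturated chain carbon bound to an aromatic carbon and a saturated chain carbon. Within the data shown here, no step between measured compounds covers this change, so its size is open. An upward step is expected, since compound 1, which also carries two phenyl groups on that chain carbon, gives 5.89. The expected step is a number 0.53 log units higher from compound 2 to compound 3 (beyond the scatter) in this assay. Compound 3 is estimated at 5.8, within 5.3 to 6.3.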

Compound 3, negative logarithm of the antagonist equilibrium constant: 6.14
Beside the measured number, compound 3's estimate is 0.34 log units below it; the measured number falls inside the stated range.
By their numbers in this assay, from the lowest: compound 2; then compounds 1 and 3 (each within the scatter of the next).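

In this assay, phenyl in place of methyl on a saturated chain carbon bound to an aromatic carbon and a saturated chain carbon gives a number 0.87 log units higher from compound 2 to compound 3 (beyond the scatter), the first measured size for this change. Pyridin-3-yl in place of phenyl on a saturated chain carbon, three bonds along the chain from an amine nitrogen, gives a number 0.25 log units higher from compound 1 to compound 3 (within the scatter), so the two groups are not told apart with two phenyl groups in place. No supporting data bear on either step. From the compounds shown here alone, whether cyclohexyl in place of the added phenyl keeps the number remains open, as does the effect of a longer chain in place of the one carrying pyridin-3-yl.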